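Thiosemicarbazide series: cytotoxicity on breast epithelial cells

The compounds below may be only part of what the source reports. "The series", "measured", "known", "first", "only" and "open" are said of these compounds alone.

Compound 1 `CCOc1ccc(NC(=S)NNC(=O)c2ccncc2)cc1`: in an ADME assay on MCF-10A cells (Homo sapiens) for cytotoxicity, read by WST assay, with a stated time of 48 h (on this read-out lower numbers stand for stronger inhibition and higher numbers for weaker inhibition), compound 1 gives > 300000 nM, a limit of the assay.
Compound 2 `CC(=O)Nc1ccc(NC(=S)NNC(=O)c2ccncc2)cc1`: compound 2 gives > 300000 nM, a limit.
Compound 3 `Cc1cccc(C)c1NC(=S)NNC(=O)c1ccncc1`: compound 3 gives > 300000 nM, a limit.

Compound 2 stands at the limit, as do the other two values shown, all at the limit of > 300000 nM in this assay, at which 3 of the 3 values shown sit. For the measured compounds named here, the one measured step, a step that the two limits leave unreadable from compound 1 to compound 2, is unreadable for that reason. Compound 4 `O=C(NNC(=S)Nc1ccc([N+](=O)[O-])cc1)c1ccncc1` differs from compound 2 by nitro in place of acetamido on an aromatic carbon. Going by the values given here, no measured step bears on this exchange with a readable size, so no direction in this assay can be expected beyond the scatter. The step expected is a step that the limit leaves unreadable from compound 2 to compound 4, most likely again a limit. For compound 4 the estimate is 400000 nM, in the range 150000 nM to 1000000 nM.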

Compound 4, half-maximal inhibitory concentration: > 300000 nM
Compound 4: only a limit was reported; the forecaster's own chance of this, stated with the estimate: 75%; the middle value is on the limit's open side.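

The steps to compound 4 from compound 1 and from compound 2 cannot be read, as all the values share one limit: the limit of > 300000 nM in this assay, at which 4 of the 4 values shown sit. Going by these compounds, whether any exchange on the shared core changes the read-out in this assay remains open.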